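This account rests on a few compounds, and the source may have more. Where it says the series, first, only, none or still open, it means among the compounds named here.

Measured compounds in an assay on CHO cells for antagonist activity at transient receptor potential cation channel subfamily V member 1 (Homo sapiens), read by FLIPR and calcium flux; on this read-out lower numbers stand for stronger inhibition and higher numbers for weaker inhibition:
Compound 1 `CC(C(=O)NCc1ccc(C(F)(F)F)nc1Br)c1ccc(NS(C)(=O)=O)c(F)c1` gives 169 nM
Compound 2 `CCCc1nc(C(F)(F)F)ccc1CNC(=O)C(C)c1ccc(NS(C)(=O)=O)c(F)c1` gives 22.7 nM
Compound 3 `CC(C(=O)NCc1ccc(C(F)(F)F)nc1C1=CCC(C)(C)CC1)c1ccc(NS(C)(=O)=O)c(F)c1` gives 0.2 nM

Compound 3 gives the lowest number of the three, with the steps of an 850-fold lower number from compound 1 to compound 3 (2.93 log units; beyond the scatter) and a 110-fold lower number from compound 2 to compound 3 (2.05 log units; beyond the scatter) both well beyond the scatter. Compound 4 `CCC/C=C/c1nc(C(F)(F)F)ccc1CNC(=O)C(C)c1ccc(NS(C)(=O)=O)c(F)c1` differs from compound 3 by one change: pent-1-en-1-yl in place of 4,4-dimethylcyclohex-1-en-1-yl on an aromatic carbon. Among the compounds with values here, the steps that bear on it are the replacements at the same aromatic carbon, a 7.4-fold lower number from compound 1 to compound 2 (0.87 log units; beyond the scatter) and a 110-fold lower number from compound 2 to compound 3 (2.05 log units; beyond the scatter), which show that a chain at this position gives a higher number than the ring. Compound 4 keeps a chain but one longer than propyl, with a double bond, so a number between those of compound 2 and compound 3 is expected. For compound 4 a value of 3 nM is estimated, within 0.5 nM to 20 nM, an expected step of a 15-fold higher number from compound 3 to compound 4 (1.18 log units; beyond the scatter).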

Compound 4, inhibition constant: 0.9 nM
Beside the measured number, compound 4's estimate is 3.3-fold (0.52 log units) above it; the measured number falls inside the stated range.
By their numbers in this assay, from the lowest: compound 3; then compound 4; then compound 2; then compound 1.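

In this assay, a ring is not needed for a low number on this aromatic carbon next to the ring nitrogen: pent-1-en-1-yl gives a 25-fold lower number from compound 2 to compound 4 (1.40 log units; beyond the scatter) and a 190-fold lower number from compound 1 to compound 4 (2.27 log units; beyond the scatter), leaving a 4.5-fold higher number from compound 3 to compound 4 (0.65 log units; beyond the scatter). The earlier contrast between propyl and the ring therefore does not extend to every chain. No supporting measurement explains this difference.

On these data alone, what a saturated pentyl chain would give stays open, so the contributions of chain length and the double bond cannot be separated. Also open, as far as these compounds go, is how a piperidine would compare with 4,4-dimethylcyclohex-1-en-1-yl here.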